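The source may report more compounds than this note shows. Statements on the series, on what has been measured and on what is new or still open speak of the compounds shown alone.

Measured compounds in a functional assay on HL60/MX2 cells (Homo sapiens) for antiproliferative activity, read by MTT assay, with a stated time of 48 h; on this read-out lower numbers stand for stronger inhibition and higher numbers for weaker inhibition:
Compound 1 `CN1CCN(CCn2c(N)c(-c3nc4ccccc4[nH]3)c3nc(C#N)c(C#N)nc32)CC1` gives 6490 nM.
Compound 2 `CCCn1c(N)c(-c2nc3ccccc3[nH]2)c2nc(C#N)c(C#N)nc21` reaches only a limit of this assay, > 50000 nM.
Compound 3 `CN1CCN(CCCn2c(N)c(-c3nc4ccccc4[nH]3)c3nc(C#N)c(C#N)nc32)CC1` gives 3320 nM.

Compound 4 `CCCCn1c(N)c(-c2nc3ccccc3[nH]2)c2nc(C#N)c(C#N)nc21` is not yet measured in this assay. It differs from compound 3 by methyl in place of 4-methylpiperazin-1-yl on a saturated chain carbon, three bonds along the chain from an aromatic nitrogen. The same kind of change has been measured once, from compound 1 to compound 2, as methyl in place of 4-methylpiperazin-1-yl on a saturated chain carbon, two bonds along the chain from an aromatic nitrogen; that step was an at least 7.7-fold higher number from compound 1 to compound 2 (0.88 log units; beyond the scatter), with compound 2 sitting at the limit of > 50000 nM in this assay, at which 1 of the 3 values shown sits. The places are not identical: in the measured pair the change sits two bonds along the chain from an aromatic nitrogen, in the new pair three bonds along it. The two cores differ by (4-methylpiperazin-1-yl)methyl in place of 4-methylpiperazin-1-yl on a saturated chain carbon, two bonds along the chain from an aromatic nitrogen, a difference that gave a 2.0-fold lower number from compound 1 to compound 3 (0.29 log units; within the scatter). Compound 4 is expected to show a step of a 12-fold higher number from compound 3 to compound 4 (1.08 log units; beyond the scatter), close to the measured one, resting on an at least 7.7-fold higher number from compound 1 to compound 2 (0.88 log units; beyond the scatter). Compound 4 is therefore estimated at 40000 nM, within 15000 nM to 120000 nM, and a limit may well be all that is reported.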

Compound 4, half-maximal inhibitory concentration: > 50000 nM
Compound 4 was reported as a limit (the forecaster's own chance of this, stated with the estimate: 60%); middle value at least 1.2-fold (0.09 log units) away from the limit.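

Replacing 3-(4-methylpiperazin-1-yl)propyl with butyl in this assay gives an at least 15-fold higher number from compound 3 to compound 4 (1.17 log units; beyond the scatter), and replacing the shorter 2-(4-methylpiperazin-1-yl)ethyl chain with butyl gives an at least 7.7-fold higher number from compound 1 to compound 4 (0.88 log units; beyond the scatter). Removing the 4-methylpiperazin-1-yl group thus moves the number the same way on both cores, but this does not show that the step has the same size on each: the same change on two cores in this assay, an at least 7.7-fold higher number (0.88 log units; beyond the scatter) from compound 1 to compound 2 and an at least 15-fold higher number (1.17 log units; beyond the scatter) from compound 3 to compound 4; the limit leaves it open whether they differ. Compound 2 and compound 4 both stand at a limit, so the step between them cannot be read: the limit of > 50000 nM in this assay, at which 2 of the 4 values shown sit.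

The compounds shown leave open whether another amine, such as morpholine or dimethylamino, would give similar values at the chain end. They also leave open how a longer chain carrying 4-methylpiperazin-1-yl would behave.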